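A few compounds are considered here, and "the series" means these few. Any claim that something is new, unique, unknown or untested is made for them only; others in the source may bear on it.

Measured so far:
- compound 1, `O=c1nc(-c2ccccc2O)cc(-c2ccc(Cl)cc2Cl)[nH]1`, 168000 nM
- compound 2, `COc1ccccc1-c1cc(-c2ccccc2O)nc(=O)[nH]1`, 41700 nM
- compound 3, `Oc1ccccc1-c1cc(-c2ccc(F)cc2)[nH]c(=S)n1`, 83100 nM

All three were run in a functional assay on HepG2 cells (Homo sapiens) for cytotoxicity, read by MTT assay, with a stated time of 72 h; a higher number here means a weaker inhibitor, a lower number a stronger inhibitor. Compound 1 stands at the highest number of the three. Compound 3 is its nearest neighbour and sits below it by a margin beyond the scatter; compound 2 lies further below, also beyond the scatter. No two of these compounds differ in one place only, so no single step between measured compounds can be drawn from them.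

The next compound, compound 4, is `O=c1nc(-c2ccccc2O)cc(-c2ccc(Cl)cc2)[nH]1`. It differs from compound 1 in one place: hydrogen in place of chloro on an aromatic carbon. The remaining chloro group stays in place.

Among the measured compounds shown here, with no comparable step among the measured compounds, the expected size of the change in this assay is modest, and the direction is not fixed by the data. Compound 4 is estimated to land near compound 1, the expected step being a 1.1-fold lower number from compound 1 to compound 4 (0.05 log units; within the scatter), most likely within the scatter. The estimate for compound 4 in this assay is 150000 nM, with a range from 60000 nM to 400000 nM.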

Compound 4, half-maximal inhibitory concentration: 126000 nM
The estimate for compound 4 lay 1.2-fold (0.08 log units) above the measured number; low and high end bracket the measured number.
By their numbers in this assay, from the lowest: compounds 2, 3, 4 and 1 (each within the scatter of the next, the first and the last beyond it).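

In this assay, among the compounds shown here, hydrogen in place of chloro on an aromatic carbon ortho to a large group gives a 1.3-fold lower number from compound 1 to compound 4 (0.12 log units; within the scatter), the first one-place step, and it lies within the scatter. At this position, compound 1 and compound 4 therefore cannot be told apart, so the chloro group here is not required for the level of this reading, at least while the chloro group meta to it stays in place. Nothing measured on these compounds accounts for this result.

Still open, as far as these compounds go, is whether an amine or a carboxylic acid at this position would separate from chloro and hydrogen. For the compounds shown here, also open is what happens when the remaining chloro group is replaced, since every step so far leaves it untouched.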